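Compound 4: nitro in place of bromo

The source may report more compounds than this note shows. Statements on the series, on what has been measured and on what is new or still open speak of the compounds shown alone.

Values from a functional assay on A549 cells (Homo sapiens) for cytotoxicity, read by MTT assay, with a stated time of 24 h (on this read-out lower numbers stand for stronger inhibition and higher numbers for weaker inhibition), follow.

Compound 1 `COc1ccc(/C=C(\C#N)C(=O)N/N=C(\C)c2c(O)c3ccc(O)cc3oc2=O)cc1OC` gives 14300 nM
Compound 2 `COc1ccc(/C=C(\C#N)C(=O)N/N=C(\C)c2c(O)c3ccc(O)cc3oc2=O)cc1` gives 8150 nM
Compound 3 `C/C(=N\NC(=O)/C(C#N)=C/c1ccc(Br)cc1)c1c(O)c2ccc(O)cc2oc1=O` gives 11400 nM

All three values lie within the scatter of one another, so compound 3 cannot be ranked against the other two. Compound 4 `C/C(=N\NC(=O)/C(C#N)=C/c1ccc([N+](=O)[O-])cc1)c1c(O)c2ccc(O)cc2oc1=O` has nitro in place of bromo on an aromatic carbon, para to a large group (nitro in place of bromo on an aromatic carbon). Going by the values given here, no nitro compound has been measured yet. The closest evidence comes from other changes on this aromatic ring: a 1.8-fold lower number from compound 1 to compound 2 (0.24 log units; within the scatter), a 1.3-fold lower number from compound 1 to compound 3 (0.10 log units; within the scatter) and a 1.4-fold higher number from compound 2 to compound 3 (0.15 log units; within the scatter). Since all of these stay small, no step beyond the scatter is expected in this assay. The expected step is a 1.1-fold lower number from compound 3 to compound 4 (0.04 log units; within the scatter). For compound 4 the estimated value is 10500 nM, with an expected range of 5000 nM to 22000 nM.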

Compound 4, half-maximal inhibitory concentration: 9640 nM
Compound 4: the middle estimate sits 1.1-fold (0.04 log units) above what was measured, within the range that was stated.
By their numbers in this assay, from the lowest: compounds 2, 4, 3 and 1 (each within the scatter of the next).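

Putting nitro in place of bromo, with more heavy atoms and two hydrogen-bond acceptors entering, gives no readable difference in this assay (a 1.2-fold lower number from compound 3 to compound 4 (0.07 log units; within the scatter)). The other two steps also stay within the scatter (a 1.2-fold higher number from compound 2 to compound 4 (0.07 log units; within the scatter) and a 1.5-fold lower number from compound 1 to compound 4 (0.17 log units; within the scatter)), so all four groupings on this aromatic ring remain indistinguishable in this read-out. No measurement at hand bears on this result.

From the compounds shown here alone, whether an amine or a carboxylic acid at this ring carbon would move the number beyond the scatter stays open. So does whether changes elsewhere on the shared core would.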